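A chloro-to-methoxy swap on a cyanopyrimidine cell assay

A few compounds are considered here, and "the series" means these few. Any claim that something is new, unique, unknown or untested is made for them only; others in the source may bear on it.

Of the compounds shown here, three have been tested in an ADME assay on Jurkat cells (Homo sapiens) for inhibition, read by WST assay, with a stated time of 48 h, tested at 10 uM; on this read-out higher numbers stand for more inhibition at the one concentration tested (going by the name of the read-out) and lower numbers for less inhibition. Compound 1 `N#Cc1c(-c2ccc(Cl)cc2)nc(SCc2ccccc2)nc1N1CCC(C(N)=O)CC1` gives 19% in this assay. Compound 2 `N#Cc1c(-c2ccc(Cl)cc2)nc(SCc2ccccc2)nc1N1CCC(C(=O)c2ccccc2)CC1` gives 6%. Compound 3 `COc1ccc(-c2nc(SCc3ccccc3)nc(NCc3cccs3)c2C#N)cc1` gives 13%. Among these, compound 2 has the lowest number: the gap to compound 3 lies within the scatter, while the gap to compound 1 lies beyond it. Among the compounds with values here, the only step between compounds that differ in one place is a number 13 percentage points lower from compound 1 to compound 2 (beyond the scatter), the change being phenyl in place of amino on a carbonyl carbon.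

Compound 4 `COc1ccc(-c2nc(SCc3ccccc3)nc(N3CCC(C(=O)c4ccccc4)CC3)c2C#N)cc1` has not been measured. It differs from compound 2 by methoxy in place of chloro on an aromatic carbon. Within the data shown here, no measured step covers this change on its own. Compound 3 carries the same 4-methoxyphenyl group and gives 13%, while compound 2 gives 6%; the two values lie within the scatter of each other, but compound 3 also differs from compound 2 in other places, so they cannot settle the question. With nothing pointing either way, the expected step is a number 3 percentage points higher from compound 2 to compound 4 (within the scatter), that is, no change beyond the scatter. Compound 4 is therefore estimated to give 9% in this assay, with a range from 0% to 22%.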

Compound 4, a percentage reported as inhibition, at one concentration (the size of the read-out at that concentration, not a potency): 2%
Beside the measured number, compound 4's estimate is 7 percentage points above it; the measured number falls inside the stated range.
By their numbers in this assay, from the lowest: compounds 4, 2, 3 and 1 (each within the scatter of the next, the first and the last beyond it).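

In this assay, within the data shown here, this pair gives the first direct reading of methoxy in place of chloro on an aromatic carbon, para to a large group: a number 4 percentage points lower from compound 2 to compound 4 (within the scatter), so going from 4-chlorophenyl to 4-methoxyphenyl produces no change beyond the usual scatter for this pair. The earlier compounds shown here could not show this, since compound 3 carries the same methoxy group but also differs from compound 2 in other places. Nothing available explains the result or links it to any measured property of either group.

As far as these compounds go, this reading comes from a single pair, both members of which carry a phenyl on the carbonyl carbon, so it remains open whether the same swap would also fall within the scatter on a compound with the amino group of compound 1 on that carbonyl carbon. Also open, from the compounds shown here alone, is how other groups at this aromatic position, such as an amine, a carboxylic acid or a longer chain, would read in this assay.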